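Dropping the oxadiazole arm from compound 1

The source may report more compounds than this note shows. Statements on the series, on what has been measured and on what is new or still open speak of the compounds shown alone.

Among the three compounds with numbers in an assay on isolated protein for inhibition of Hematopoietic prostaglandin D synthase (Homo sapiens), read by fluorescence polarization (a higher number here means a weaker inhibitor, a lower number a stronger inhibitor), compound 1 `CC(C)(O)c1nc(-c2cccc(CNC(=O)c3cnc(-c4ccccn4)nc3)c2)no1` gives 7.48 nM, the lowest of the set. Among the measured compounds shown here, compound 2 `O=C(NCc1ccccc1)c1ccc(-c2ccccc2)nc1` gives 122 nM, and compound 3 `O=C(NCc1ccccc1)c1ccc(-c2ccccn2)nc1` gives 80.7 nM; the one counted step among them, a 1.5-fold lower number from compound 2 to compound 3 (0.18 log units; within the scatter), is small. Compound 1 thus stands well apart from both, with its nearest neighbour compound 3 still far higher.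

Compound 4 `O=C(NCc1ccccc1)c1cnc(-c2ccccn2)nc1` is compound 1 with one piece cut away: hydrogen in place of 5-(1-hydroxy-1-methylethyl)-1,2,4-oxadiazol-3-yl on an aromatic carbon. The group that leaves carries a hydroxyl as its one donor and four acceptors; what remains is the bare benzylamide on the shared core.

For the measured compounds named here, no measured step covers exactly this cut. The closest guide is compound 3, which also carries an unsubstituted benzylamide and a pyridin-2-yl group but on a different core, and its value sits well above that of compound 1. Taken together this suggests that the loss of the arm costs potency, so a clear rise in this assay is expected, an 8.0-fold higher number from compound 1 to compound 4 (0.90 log units; beyond the scatter), landing near the level of compound 3.

Compound 4 is therefore estimated at 60 nM, with a likely range from 20 nM to 200 nM.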

Compound 4, half-maximal inhibitory concentration: 7.14 nM
Estimate against measurement, compound 4: 8.4-fold (0.92 log units) above, outside the stated range (below it).
By their numbers in this assay, from the lowest: compounds 4 and 1 (each within the scatter of the next); then compounds 3 and 2 (each within the scatter of the next).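

Hydrogen takes the place of the whole 5-(1-hydroxy-1-methylethyl)-1,2,4-oxadiazol-3-yl arm in this step. In this assay the step reads a 1.0-fold lower number from compound 1 to compound 4 (0.02 log units; within the scatter), and on this aromatic carbon of a six-membered aromatic ring of carbon only, the arm and a bare hydrogen cannot be told apart by this read-out. Among the compounds shown here, the low number of compound 1 therefore does not depend on the arm, and its distance from the earlier compounds has to be read differently: compound 3, a bare benzylamide on a different core, gives 80.7 nM and compound 4, a bare benzylamide on the shared core, gives 7.14 nM as its number. Nothing available here offers an explanation for why the arm can leave without a visible change in the number.

From the compounds shown here alone, whether this aromatic carbon accepts anything at all remains open, since an amine, a carboxylic acid or a longer chain placed there could still shift the number in either direction. Also open, going by these compounds, is whether the arm, silent in this one assay on isolated protein, would matter in a measurement of any other kind.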